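This account rests on a few compounds, and the source may have more. Where it says the series, first, only, none or still open, it means among the compounds named here.

Measured so far:
Compound 1 `O=C(O)Cc1sc(C(Cc2ccccc2)c2ccccc2)nc1-c1ccc(Cl)cc1` in an in vitro assay on HEK385-7 cells for displacement of a labelled ligand from prostaglandin D2 receptor 2 (Homo sapiens); a lower number here means a stronger inhibitor, a higher number a weaker inhibitor: 56 nM
Compound 2 `O=C(O)Cc1sc(C(c2ccc(F)cc2)c2ccc(F)cc2)nc1-c1ccco1` in this assay: 18 nM

Of the two numbers, compound 2 gives the lower one; the number of compound 1 lies above it by more than the usual scatter. Among the compounds with values here, the two compounds differ in more than one place, so no single step between measured compounds is available and nothing isolates the part played by the aromatic group on the core.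

Compound 3 `CN(C)c1cc(-c2nc(C(c3ccc(F)cc3)c3ccc(F)cc3)sc2CC(=O)O)ccn1` follows from compound 2 by one change: 2-(dimethylamino)pyridin-4-yl in place of furan-2-yl on an aromatic carbon. Both groups are uncharged aromatic rings carrying no hydrogen-bond donor; the incoming ring is larger and carries one acceptor more, as counted.

Within the data shown here, with no measured step on this position, the expectation rests on compound 2 alone. The step of a 1.1-fold higher number from compound 2 to compound 3 (0.05 log units; within the scatter) is expected to be small, with no clear direction, and most likely within the scatter, in either direction by a modest amount at most. Compound 3 is therefore expected near 20 nM, in the range 7 nM to 60 nM.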

Compound 3, half-maximal inhibitory concentration: 380 nM
The estimate for compound 3 lay 19-fold (1.28 log units) below the measured number; the whole stated range lies below it.
By their numbers in this assay, from the lowest: compound 2; then compound 1; then compound 3.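

In this assay the aromatic carbon next to the ring nitrogen and next to the ring atom that bears a carboxymethyl group proves sensitive to its substituent: 2-(dimethylamino)pyridin-4-yl in place of furan-2-yl gives a 21-fold higher number from compound 2 to compound 3 (1.32 log units; beyond the scatter) on the shared core. Within the data shown here, this is the first single-place step, and it shows that an exchange between two uncharged aromatic rings, neither carrying a hydrogen-bond donor, can still produce a large change in this assay, so those shared counted features do not keep the number steady. The incoming group differs in ring size, heavy-atom count and acceptor count, but no measurement here connects the step to any of these differences.

The compounds shown leave open whether the step belongs to the dimethylamino group or to the six-membered ring itself; an unsubstituted pyridin-4-yl or a phenyl ring on this carbon would separate the two. Among these compounds, also open is whether a step of this size would recur with the other large group, the one carried by compound 1, on the shared core.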